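From Fluoro to 2-Methylphenyl: An Expected Gain in Potency

The source may report more compounds than this note shows. Statements on the series, on what has been measured and on what is new or still open speak of the compounds shown alone.

Three compounds have been measured in an in vitro functional assay on 1321-N1 cells for agonist activity at Free fatty acid receptor 1 (Homo sapiens), read by fluorescence, spectrophotometry and calcium flux; on this read-out higher numbers stand for an effect only at larger amounts of compound and lower numbers for an effect already at smaller amounts:

Compound 1 `Cc1c(C#Cc2ccc(CCC(=O)O)cc2)cc(Cl)nc1Cl` gives 43.7 nM.
Compound 2 `O=C(O)CCc1ccc(C#Cc2ccnc(F)c2)cc1` gives 513 nM.
Compound 3 `O=C(O)CCc1ccc(C#Cc2cccnc2)cc1` gives 6030 nM.

Compound 2 stands in the middle of these three numbers, the second highest. Compound 1 sits well below it, at a distance beyond the usual scatter, while compound 3 sits well above it, also beyond the scatter. Both neighbours thus differ from compound 2 in a way that repeated measurement would not blur.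

Compound 4 `Cc1ccccc1-c1cc(C#Cc2ccc(CCC(=O)O)cc2)ccn1` has not yet been measured. Its difference from compound 2 is 2-methylphenyl in place of fluoro on an aromatic carbon. Among the measured compounds shown here, no measured pair in this set shares exactly this change, so the expected size of the step rests on the spread of the three numbers alone. In this assay a step to a lower number is expected for compound 4, roughly the size seen between compound 2 and compound 1, which is beyond the scatter. The expected step from compound 2 to compound 4 is a 5.1-fold lower number from compound 2 to compound 4 (0.71 log units; beyond the scatter). Compound 4 is estimated at 100 nM, with a range from 20 nM to 500 nM.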

Compound 4, half-maximal effective concentration: 1070 nM
The estimate for compound 4 lay 11-fold (1.03 log units) below the measured number; measured number outside the range, above it.
By their numbers in this assay, from the lowest: compound 1; then compound 2; then compound 4; then compound 3.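

In this assay, 2-methylphenyl in place of fluoro on an aromatic carbon next to the ring nitrogen gives a 2.1-fold higher number from compound 2 to compound 4 (0.32 log units; beyond the scatter) and so does not bring the gain that compounds with a lower number might have suggested. The change replaces 1 heavy atom with 7 heavy atoms, including a whole six-membered aromatic ring, yet the step is only modest, so this position can carry a far larger group while the compound keeps much of its activity. The data shown offer no measurement that explains why the number rises.

Going by these compounds, it remains open whether a small group at this place, such as a methyl or an amine, would give a lower number than fluoro. Also open, on these data alone, is whether plain phenyl, without the methyl, would behave like 2-methylphenyl.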